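The source may report more compounds than this note shows. Statements on the series, on what has been measured and on what is new or still open speak of the compounds shown alone.

Measured compounds:
- Compound 1 `Cc1ccc(SCc2ccc(/C=C/C(=O)Nc3ccccc3N)cc2)cc1`: 25.5%
- Compound 2 `Nc1ccccc1NC(=O)/C=C/c1ccc(CSc2ccc(Cl)cc2)cc1`: 1.94%
- Compound 3 `CC(C)(C)c1ccc(SCc2ccc(/C=C/C(=O)Nc3ccccc3N)cc2)cc1`: 17.5%

All three values come from a functional assay on HeLa cells (Homo sapiens) for inhibition, read by CCK-8 assay, with a stated time of 72 h, tested at 2 uM; a lower number here means less inhibition of growth, a higher number more inhibition of growth at the concentration tested. Compound 3 stands second highest of the three, and compound 1 lies nearest to it, a number only within the scatter apart, so the two cannot be ranked against each other. Compound 2 lies furthest, and the step of a number 15.6 percentage points higher from compound 2 to compound 3 (beyond the scatter) shows a modest rise.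

Compound 4 `Nc1ccccc1NC(=O)/C=C/c1ccc(CSCCc2ccccc2)cc1` differs from compound 3 in one place: phenethyl in place of 4-(tert-butyl)phenyl on a sulfur. Among the measured compounds shown here, no measured step swaps the whole group on this sulfur; the steps seen only vary a substituent on that aromatic ring. Of those, a number 8 percentage points lower from compound 1 to compound 3 (within the scatter) stays within the scatter, while a number 23.6 percentage points lower from compound 1 to compound 2 (beyond the scatter) is a modest fall. So the data show that changes at this end can move the number modestly, but give no direction for a phenethyl group. With all three measured values low, a shift no larger than the scatter is expected, so a number 2.5 percentage points lower from compound 3 to compound 4 (within the scatter) is the expected step. Compound 4 is estimated at 15% in this assay, with a range of 0% to 32%.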

Compound 4, percent growth inhibition at one concentration: 0.19%
Compound 4: middle estimate off by 14.8 percentage points, on the high side, and the stated range covers the measured number.
By their numbers in this assay, from the lowest: compounds 4 and 2 (each within the scatter of the next); then compounds 3 and 1 (each within the scatter of the next).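

The earlier compounds shown here only varied a substituent on the aromatic ring carried by the sulfur, whereas here that whole group gives way to phenethyl. In this assay this swap brings the number down modestly from both the 4-(tert-butyl)phenyl compound (a number 17.3 percentage points lower from compound 3 to compound 4 (beyond the scatter)) and the 4-methylphenyl compound (a number 25.3 percentage points lower from compound 1 to compound 4 (beyond the scatter)), while against the 4-chlorophenyl compound the two values cannot be told apart (a number 1.8 percentage points lower from compound 2 to compound 4 (within the scatter)). Phenethyl therefore sits at the low end with chloro, showing that more than one kind of change at this sulfur can leave almost no growth inhibition, and nothing measured here gives a reason for these steps.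

Still open, from the compounds shown here alone, is whether a benzyl group or a longer phenylpropyl chain on the sulfur would behave like phenethyl. Also open, going by these compounds, is whether an amine or a carboxylic acid on that aromatic ring would raise the number.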